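One Methyl Added to a Ring Hydroxyl

A few compounds are considered here, and "the series" means these few. Any claim that something is new, unique, unknown or untested is made for them only; others in the source may bear on it.

Measured compounds:
compound 1 `O=C(/C=C/c1ccc(O)c(O)c1)OCc1c(-c2ccccc2)no[n+]1[O-]` — > 50000 nM
compound 2 `COc1cc(/C=C/C(=O)OC/C=C/CO[N+](=O)[O-])ccc1O` — 2340 nM

Of the compounds shown here, two have been tested in a functional assay on NCI-H1299 cells (Homo sapiens) for cytotoxicity, read by resazurin assay, with a stated time of 72 h; a lower number here means a stronger inhibitor, a higher number a weaker inhibitor. Compound 1 gives > 50000 nM, which is a limit of the assay rather than a measured number. Compound 2, which shares the 4-hydroxy-3-methoxyphenyl group but carries a different ester part, gives 2340 nM in this assay. For the measured compounds named here, no pair of measured compounds differs in a single place, so no step size between them can be read off.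

Compound 3 `COc1cc(/C=C/C(=O)OCc2c(-c3ccccc3)no[n+]2[O-])ccc1O` is the next compound to be measured. It differs from compound 1 by methyl in place of hydrogen on an oxygen on an aromatic ring. This is a small change, and the ester part of compound 1 is kept unchanged. The value of compound 1 itself is known only as the limit of > 50000 nM in this assay, at which 1 of the 2 values shown sits, so the starting point is not a firm number.

Given this, the step from compound 1 to compound 3 is expected to be modest, an at least 1.6-fold lower number from compound 1 to compound 3 (0.22 log units; that floor lies within the scatter), in the direction of a somewhat stronger inhibitor, but with much uncertainty. Compound 3 is estimated at 30000 nM in this assay, within a range of 5000 nM to 100000 nM.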

Compound 3, half-maximal inhibitory concentration: 12900 nM
Compound 3: middle estimate off by 2.3-fold (0.37 log units), on the high side, and the stated range covers the measured number.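

Adding one methyl to the ring oxygen, which turns 3,4-dihydroxyphenyl into 4-hydroxy-3-methoxyphenyl, gives an at least 3.8-fold lower number from compound 1 to compound 3 (0.58 log units; beyond the scatter) in this assay, a shift beyond the usual scatter of repeated measurements. Compound 3, at 12900 nM, shows that the ester part of compound 1 can give a measurable value in this assay once this oxygen carries a methyl, so a free hydroxy at this place is not needed for a measured effect on these cells. The step is only a floor and its true size remains unknown because of where compound 1 stands: the limit of > 50000 nM in this assay, at which 1 of the 3 values shown sits.

The compounds shown leave open whether a larger group on this oxygen, such as ethyl or a longer chain, would lower the number further, and what an amine in place of this oxygen would do. On these data alone, they also give no reading of the same hydroxy to methoxy change with the ester part of compound 2, so it remains unknown whether this step holds beyond the ester part of compound 1.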